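Swapping bromo for benzyloxy: an expected cytotoxicity reading

This account rests on a few compounds, and the source may have more. Where it says the series, first, only, none or still open, it means among the compounds named here.

Compound 1, `O=C(/C=C/c1ccc2c(c1)B(O)OC2)c1ccc(C(F)(F)F)cc1`, gives > 10 ug/mL in an ADME assay on L929 cells (Mus musculus) for cytotoxicity, read by resazurin assay, with a stated time of 72 h; on this read-out higher numbers stand for weaker inhibition and lower numbers for stronger inhibition; this is a limit of the assay, not a number.
Compound 2, `O=C(O)c1ccc(C(=O)/C=C/c2ccc3c(c2)B(O)OC3)cc1`, gives > 10 ug/mL in this assay; this too is only a limit.
Compound 3, `O=C(/C=C/c1ccc2c(c1)B(O)OC2)c1ccc(Br)cc1`, gives > 10 ug/mL in this assay; this as well is only a limit.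

The three measured steps cannot be sized because every reading sits at the limit of > 10 ug/mL in this assay, at which 3 of the 3 values shown sit: a step that the two limits leave unreadable from compound 1 to compound 2, a step that the two limits leave unreadable from compound 1 to compound 3 and a step that the two limits leave unreadable from compound 2 to compound 3. Compound 3 therefore stands at the limit, and the two other values shown stand there with it, so no ordering among the three can be drawn.

Compound 4, `O=C(/C=C/c1ccc2c(c1)B(O)OC2)c1ccc(OCc2ccccc2)cc1`, has yet to be tested. Its structure departs from compound 3 in one place: benzyloxy in place of bromo on an aromatic carbon. Going by the values given here, none of the measured steps bears a readable size, so they give no direction for this change; what they do show is that every measured compound, whatever its substituent on that aromatic carbon, remains at the limit. Compound 4 is therefore expected to read at or beyond the limit too, and the step from compound 3 to compound 4 in this assay is expected to be a step that the limit leaves unreadable from compound 3 to compound 4. The estimate for compound 4 is 15 ug/mL, with a range from 5 ug/mL to 50 ug/mL.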

Compound 4, half-maximal inhibitory concentration: > 10 ug/mL
Compound 4: no number, only a limit (the forecaster's own chance of this, stated with the estimate: 80%); the middle value is on the limit's open side.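

Compound 4 also gives only a limit, so none of its steps from compound 1, compound 2 or compound 3 can be read, because all four compounds share the same reading: the limit of > 10 ug/mL in this assay, at which 4 of the 4 values shown sit. The compounds shown leave open how the four rank against one another and at what concentration any of them becomes toxic to the cells.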